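Adding a second chloro to compound 3

This account rests on a few compounds, and the source may have more. Where it says the series, first, only, none or still open, it means among the compounds named here.

Measured so far in a functional assay on A549 cells (Homo sapiens) for antiproliferative activity, read by MTT assay, with a stated time of 48 h; a lower number here means a stronger inhibitor, a higher number a weaker inhibitor:
- compound 1 `c1ccc(-c2nn(-c3ccccc3)cc2-c2nc3ccccc3[nH]2)cc1`: 2710 nM
- compound 2 `Fc1ccc(-c2nn(-c3ccccc3)cc2-c2nc3cc(Cl)ccc3[nH]2)cc1`: 1320 nM
- compound 3 `Clc1ccc(-c2nn(-c3ccccc3)cc2-c2nc3ccccc3[nH]2)cc1`: 5960 nM

Compound 3 has the highest number of the three, which makes it the weakest inhibitor here. Compound 1 lies closest to it and compound 2 furthest away. The next compound, compound 4 `Clc1ccc(-c2nn(-c3ccccc3)cc2-c2nc3cc(Cl)ccc3[nH]2)cc1`, differs from compound 3 in one place: chloro in place of hydrogen on an aromatic carbon.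

Within the data shown here, only one measured step swaps a hydrogen for chloro: a 2.2-fold higher number from compound 1 to compound 3 (0.34 log units; beyond the scatter). That chloro sits on a different carbon, so it is a weak guide to the new place. Compound 2 is more informative, since it already carries the new chloro but has fluoro instead of the older chloro, and compound 2 gives 1320 nM. A modest step towards a lower number in this assay therefore seems likely, though the evidence is thin.

The expected step is a 2.1-fold lower number from compound 3 to compound 4 (0.33 log units; beyond the scatter). For compound 4 the estimate is 2800 nM, with an expected range from 1200 nM to 6000 nM.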

Compound 4, half-maximal inhibitory concentration: 1340 nM
Estimate against measurement, compound 4: 2.1-fold (0.32 log units) above; the measured number falls inside the stated range.
By their numbers in this assay, from the lowest: compounds 2 and 4 (each within the scatter of the next); then compound 1; then compound 3.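

In this assay, among these compounds, the new chloro gives a 4.4-fold lower number from compound 3 to compound 4 (0.65 log units; beyond the scatter), the first direct reading of this carbon on the fused system of two rings. The same swap of hydrogen for chloro at the earlier place went the opposite way, a 2.2-fold higher number from compound 1 to compound 3 (0.34 log units; beyond the scatter), so its outcome depends on where the chloro sits. With the new chloro present, the other halogen site shows a 1.0-fold higher number from compound 2 to compound 4 (0.01 log units; within the scatter), which means fluoro and chloro cannot be told apart there. No measurement available here explains either shift.

From the compounds shown here alone, it remains open whether a different group on this same carbon, such as an amine or a methoxy group, would give a number like that of chloro. Going by these compounds, it is also open whether a bromo at this carbon would do the same.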